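A few compounds are considered here, and "the series" means these few. Any claim that something is new, unique, unknown or untested is made for them only; others in the source may bear on it.

Of the compounds shown here, three have been measured so far. In a functional assay on MOLT-4 cells (Homo sapiens) for cytotoxicity (a higher number here means a weaker inhibitor, a lower number a stronger inhibitor), compound 1 (`Cc1ccc(S(=O)(=O)N/C(=N\O)Nc2ccc(Cl)cc2)cc1`) gives 6 ug/mL and compound 2 (`O=S(=O)(N/C(=N\O)Nc1ccc(Cl)cc1)c1ccccc1`) gives 7 ug/mL, two values within the scatter of each other. Compound 3 (`Cc1c(S(=O)(=O)N/C(=N\O)Nc2ccc(Cl)cc2)sc2ccc(Cl)cc12`) gives 38 ug/mL, a clearly higher number than either, which leaves compound 2 at the low end of the three alongside compound 1.

Compound 4 (`N#Cc1c(Cl)cccc1Oc1ccc(S(=O)(=O)N/C(=N\O)Nc2ccc(Cl)cc2)cc1`) has not yet been measured. It departs from compound 2 by 3-chloro-2-cyanophenoxy in place of hydrogen on an aromatic carbon, with 3-chloro-2-cyanophenoxy in place of hydrogen on an aromatic carbon, para to a large group.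

Going by the values given here, the one measured step that bears on this change is a 1.2-fold higher number from compound 1 to compound 2 (0.07 log units; within the scatter), with hydrogen in place of methyl on an aromatic carbon. That step lies within the scatter, but it involves only a methyl and says little about a group of this size. The sole measured hint for a larger aromatic portion in that part of the structure is compound 3 at 38 ug/mL, and it points toward a higher number. The support is thin, so only a moderate rise is expected, and the estimated change is a 1.7-fold higher number from compound 2 to compound 4 (0.23 log units; within the scatter). For compound 4 the estimate is 12 ug/mL, with an expected range of 4 ug/mL to 40 ug/mL.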

Compound 4, half-maximal inhibitory concentration: 95 ug/mL
Compound 4: middle estimate off by 7.9-fold (0.90 log units), on the low side, outside the stated range (above it).
By their numbers in this assay, from the lowest: compounds 1 and 2 (each within the scatter of the next); then compound 3; then compound 4.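

In this assay, the aromatic carbon para to a large group proves far from indifferent to what it carries: 3-chloro-2-cyanophenoxy in place of hydrogen gives a 14-fold higher number from compound 2 to compound 4 (1.13 log units; beyond the scatter), and the same group in place of methyl gives a 16-fold higher number from compound 1 to compound 4 (1.20 log units; beyond the scatter). Going by these compounds alone, the earlier change at this carbon, hydrogen in place of methyl, gave a 1.2-fold higher number from compound 1 to compound 2 (0.07 log units; within the scatter), which lies within the scatter, so only this much larger group, with its 10 heavy atoms and its six-membered aromatic ring, shows that a change here can move the number well beyond the scatter. Within the data shown here, nothing available explains why this group moves the number so far.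

The compounds shown leave open which part of the entering group accounts for the step, since only one such group appears at this carbon: an unsubstituted phenoxy, or a phenoxy carrying only the nitrile or only the chlorine, would begin to separate those parts. They also leave open how a small group other than methyl would read here, such as a methoxy, an amine or a carboxylic acid.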